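Nitrofuran Amide Series: Vero Cell Cytotoxicity Notes

The compounds below may be only part of what the source reports. "The series", "measured", "known", "first", "only" and "open" are said of these compounds alone.

Compound 1 `O=C(Nc1nc(-c2ccccc2)cs1)c1ccc([N+](=O)[O-])o1` gives 41700 nM in an ADME assay on Vero cells (Chlorocebus sabaeus) for cytotoxicity, read by MTT assay, with a stated time of 72 h (on this read-out lower numbers stand for stronger inhibition and higher numbers for weaker inhibition), the only number shown for the series. Compound 2 `CCOc1cccc(-c2csc(NC(=O)c3ccc([N+](=O)[O-])o3)n2)c1` reaches only a limit there, > 90000 nM. For the measured compounds named here, the one measured step, an at least 2.1-fold higher number from compound 1 to compound 2 (0.33 log units; beyond the scatter), is bounded by the limit of > 90000 nM in this assay, at which 1 of the 2 values shown sits. Compound 3 `CC(=O)Nc1cccc(-c2csc(NC(=O)c3ccc([N+](=O)[O-])o3)n2)c1` differs from compound 1 by acetamido in place of hydrogen on an aromatic carbon. This change, like the ethoxy step, places a group on an aromatic carbon meta to a large group, so a comparable move toward higher numbers is expected in this assay. Compound 3 is therefore estimated at 80000 nM (range 35000 nM to 150000 nM). That corresponds to an expected step of a 1.9-fold higher number from compound 1 to compound 3 (0.28 log units; within the scatter).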

Compound 3, half-maximal inhibitory concentration: 57600 nM
Estimate against measurement, compound 3: 1.4-fold (0.14 log units) above; the range from low to high includes it.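

In this assay, acetamido on this aromatic carbon, meta to a large group, gives a 1.4-fold higher number from compound 1 to compound 3 (0.14 log units; within the scatter), so unlike the ethoxy step, this change leaves no shift beyond the scatter. Exchanging ethoxy for acetamido gives an at least 1.5-fold lower number from compound 2 to compound 3 (0.19 log units; that floor lies within the scatter). The size of that gap stays unfixed because compound 2 carries a limit and not a number: the limit of > 90000 nM in this assay, at which 1 of the 3 values shown sits.

Still open, as far as these compounds go, is whether an amine or a carboxylic acid on this carbon would stay within the scatter. Also open, from the compounds shown here alone, is what a longer chain than ethoxy would do.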